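Shortening the acyl chain: from compound 2 to compound 4

A few compounds are considered here, and "the series" means these few. Any claim that something is new, unique, unknown or untested is made for them only; others in the source may bear on it.

The series shares one core carrying an acyl group on the ring nitrogen and an anilide on the other side. Compound 1 `CCCCCCCCC(=O)N1c2ccccc2CCC1C(=O)Nc1ccccc1O` gives 38400 nM in a functional assay on HCT-15 cells (Homo sapiens) for cytotoxicity, read by sulforhodamine B assay, with a stated time of 72 h; on this read-out higher numbers stand for weaker inhibition of growth and lower numbers for stronger inhibition of growth. Compound 2 `CCCC(=O)N1c2ccccc2CCC1C(=O)Nc1cc(C(F)(F)F)cc(C(F)(F)F)c1` gives 21900 nM in this assay, the lower of the two numbers, though its gap to compound 1 is within the scatter, so no order between them is claimed. For compound 3 `CCCC(=O)N1c2ccccc2CCC1C(=O)Nc1ccccc1C(F)(F)F` this assay returns only a limit, > 70000 nM, and the limit of > 70000 nM in this assay, at which 1 of the 3 values shown sits, marks where that value sits.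

Compound 4 `CCC(=O)N1c2ccccc2CCC1C(=O)Nc1cc(C(F)(F)F)cc(C(F)(F)F)c1` is not yet measured. Against compound 2 the difference is hydrogen in place of methyl on a saturated chain carbon, two bonds along the chain from a carbonyl carbon, the same difference read one bond further out as propylcarbonyl to propanoyl. Among the measured compounds shown here, no measured step in this assay isolates such a change, and compound 1 with its longer chain does not separate from compound 2 beyond the scatter. The step from compound 2 to compound 4 is therefore expected to be small, a 1.1-fold higher number from compound 2 to compound 4 (0.06 log units; within the scatter), in no particular direction. For compound 4 the estimate in this assay is 25000 nM, between 10000 nM and 62000 nM.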

Compound 4, concentration for 50% growth inhibition: 7620 nM
For compound 4 the middle estimate is 3.3-fold (0.52 log units) above the measured one, and the stated range ends above it.
By their numbers in this assay, from the lowest: compound 4; then compounds 2 and 1 (each within the scatter of the next). At a limit, above all of these: compound 3.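

In this assay, among the compounds shown here, the acyl chain turns out to be a responsive position: hydrogen in place of methyl on a saturated chain carbon, two bonds along the chain from a carbonyl carbon, gives a 2.9-fold lower number from compound 2 to compound 4 (0.46 log units; beyond the scatter), the first single-place step and one that lies beyond the scatter. The change of propylcarbonyl to propanoyl therefore matters with this anilide held fixed, which compound 1 could not show, since it differs from compound 2 in more than one place. For the compounds shown here, nothing measured so far bears on the reason for this step.

On these data alone, a single step sets no trend, so whether acetyl or a longer chain such as pentanoyl would follow the same direction remains open. Whether the propanoyl group acts alike on other anilides, such as one carrying an amine, is equally unresolved.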